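Notes on a three-compound series and one open estimate

The compounds below may be only part of what the source reports. "The series", "measured", "known", "first", "only" and "open" are said of these compounds alone.

Values are from a functional assay on HCT-116 cells (Homo sapiens) for antiproliferative activity, read by CCK-8 assay, with a stated time of 72 h, tested at 8 uM; a lower number here means a weaker effect, a higher number a stronger effect of the compound at the concentration tested:
compound 1, `CC(C)n1cnc2c(Nc3ccccc3)nc(NCOCc3ccc(C(=O)Nc4ccccc4N)cc3)nc21`: 18.8%
compound 2, `CC(C)n1cnc2c(Nc3ccccc3)nc(NCOCc3ccc(/C=C/C(=O)Nc4ccccc4N)cc3)nc21`: 41.7%
compound 3, `CC(C)n1cnc2c(Nc3cccc(Cl)c3)nc(NCOCc3ccc(C(=O)Nc4ccccc4N)cc3)nc21`: 63.4%

Two single-point steps are measured. a number 22.9 percentage points higher from compound 1 to compound 2 (beyond the scatter); the change is 2-((2-aminophenyl)carbamoyl)ethenyl in place of (2-aminophenyl)carbamoyl on an aromatic carbon. a number 44.6 percentage points higher from compound 1 to compound 3 (beyond the scatter). Compound 3 stands highest of the three, with compound 2 nearest to it.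

Compound 4, `CC(C)n1cnc2c(Nc3cccc(Cl)c3)nc(NCOCc3ccc(/C=C/C(=O)Nc4ccccc4N)cc3)nc21`, is not yet measured in this assay. It differs from compound 3 by 2-((2-aminophenyl)carbamoyl)ethenyl in place of (2-aminophenyl)carbamoyl on an aromatic carbon. The place is the same word for word as for the pair of compound 1 and compound 2, so this is the same change, made on a core that differs by chloro in place of hydrogen on an aromatic carbon.

A step of a number 16.6 percentage points higher from compound 3 to compound 4 (beyond the scatter) is expected, somewhat smaller than the earlier a number 22.9 percentage points higher from compound 1 to compound 2 (beyond the scatter), because compound 3 already stands at 63.4%. Compound 4 is thus estimated at 80%, expected between 65% and 94%.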

Compound 4, a percentage reported as inhibition, at one concentration (the size of the read-out at that concentration, not a potency): 27.9%
Compound 4: the middle estimate sits 52.1 percentage points above what was measured; measured number outside the range, below it.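

Carrying 2-((2-aminophenyl)carbamoyl)ethenyl in place of (2-aminophenyl)carbamoyl onto the chloro-bearing core reverses the direction seen on the core of compound 1, with a number 35.5 percentage points lower from compound 3 to compound 4 (beyond the scatter) in this assay: the same change on two cores in this assay, a number 22.9 percentage points higher (beyond the scatter) from compound 1 to compound 2 and a number 35.5 percentage points lower (beyond the scatter) from compound 3 to compound 4, 58.4 percentage points apart, beyond the scatter of two such steps.
The chloro change likewise depends on which of the two side chains is present, with a number 13.8 percentage points lower from compound 2 to compound 4 (beyond the scatter): the same change on two cores in this assay, a number 44.6 percentage points higher (beyond the scatter) from compound 1 to compound 3 and a number 13.8 percentage points lower (beyond the scatter) from compound 2 to compound 4, 58.4 percentage points apart, beyond the scatter of two such steps.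
Neither change therefore adds up across these four compounds, and this read-out at a single concentration shows neither the reason for the reversal nor whether it would recur on another core.

Still open, going by these compounds, is whether the reversal persists with fluoro, methyl or methoxy in place of chloro. Also open, on these data alone, is how a longer chain in place of ethenyl would behave on either core.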